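This account rests on a few compounds, and the source may have more. Where it says the series, first, only, none or still open, it means among the compounds named here.

Compound 1 `O=C(CSc1nnc(NC(=O)CCl)s1)Nc1ccc(Br)cn1` gives 13900 nM in a functional assay on A875 cells (Homo sapiens) for antiproliferative activity, read by MTT assay, with a stated time of 48 h; on this read-out lower numbers stand for stronger inhibition and higher numbers for weaker inhibition.
Compound 2 `O=C(CCl)Nc1ccc(SCC(=O)Nc2ccc(Cl)cn2)cc1` gives 98 nM in this assay.
Compound 3 `O=C(CCCCl)Nc1ccc(SCC(=O)Nc2ccc(Cl)cn2)cc1` reaches only > 80000 nM in this assay, which is a limit of the assay and not a number.

Compound 3 therefore stands at the limit of > 80000 nM in this assay, at which 1 of the 3 values shown sits, the weakest position the numbers allow. Compound 4 `CC(C)(C)C(=O)Nc1ccc(SCC(=O)Nc2ccc(Cl)cn2)cc1` differs from it by tert-butyl in place of 3-chloropropyl on a carbonyl carbon. For the measured compounds named here, the only measured step at this position is an at least 810-fold higher number from compound 2 to compound 3 (2.91 log units; beyond the scatter), where the chloro on a saturated chain carbon bound to the carbonyl was lost; compound 4 carries no chlorine on that chain either, and no measured compound carries a tert-butyl. The account therefore expects compound 4 to stay weak, with a step of an at least 1.3-fold lower number from compound 3 to compound 4 (0.12 log units; that floor lies within the scatter) that may well again end at the limit. The estimate for compound 4 is 60000 nM, between 15000 nM and 200000 nM.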

Compound 4, half-maximal inhibitory concentration: > 80000 nM
Compound 4: no number, only a limit (the forecaster's own chance of this, stated with the estimate: 50%); at least 1.3-fold (0.12 log units) between middle value and limit.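

Tert-butyl in place of chloromethyl on a carbonyl carbon gives an at least 810-fold higher number from compound 2 to compound 4 (2.91 log units; beyond the scatter). The loss seen with compound 3 therefore recurs with a second, differently shaped group that carries no chlorine, and at this position only the chloromethyl of compound 2 keeps a readable value: the limit of > 80000 nM in this assay, at which 2 of the 4 values shown sit. The step between compound 3 and compound 4 cannot be read. The compounds shown leave open whether the chlorine itself or the chain length and shape decides the result. A bromomethyl or a plain methyl on that carbonyl carbon could separate these.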